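The compounds below may be only part of what the source reports. "The series", "measured", "known", "first", "only" and "open" are said of these compounds alone.

Of the compounds shown here, three have been tested in a functional assay on KM12 cells (Homo sapiens) for cytotoxicity, read by sulforhodamine B assay, with a stated time of 48 h, tested at 0.001 uM; a higher number here means a weaker effect of the compound at the concentration tested, a lower number a stronger effect. Compound 1 `COc1cc(C)cc(-c2nn(CC#N)cc2-c2ccc(-c3cccc(C(C)=O)c3)nc2)c1` gives 99%, compound 2 `Cc1cc(O)cc(-c2nn(CC#N)cc2-c2ccnc(-c3ccc(Oc4ccccc4)cc3)c2)c1` gives 91%, and compound 3 `COc1cc(C)cc(-c2nn(CC#N)cc2-c2ccnc(-c3ccc(N(C)C)cc3)c2)c1` gives 93%. In this assay compound 3 lies between the other two numbers, but both gaps, to compound 2 and to compound 1, fall within the usual scatter of repeated measurements, so the three compounds cannot be told apart on these numbers.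

The step under consideration leads from compound 3 to compound 4 `Cc1cc(O)cc(-c2nn(CC#N)cc2-c2ccnc(-c3ccc(N(C)C)cc3)c2)c1`, which has not yet been measured. The difference between them is hydrogen in place of methyl on an oxygen on an aromatic ring. Compound 2 already carries the same hydroxy-bearing aryl group, and its value in this assay sits within the scatter of that of compound 3.

Given that, compound 4 is expected to show a step of no change at the digits printed from compound 3 to compound 4 (within the scatter) in this assay, which is to say none beyond the scatter. Compound 4 is therefore estimated to give 93% in this assay, with a likely range from 82% to 100%.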

Compound 4, a percentage reported as activity, at one concentration (the size of the read-out at that concentration, not a potency): 91%
Compound 4: middle estimate off by 2 percentage points, on the high side, and the stated range covers the measured number.
By their numbers in this assay, from the lowest: compounds 2, 4, 3 and 1 (each within the scatter of the next).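

In this assay, among these compounds, the exchange of methoxy for hydroxy gives the first direct reading at this oxygen on the aromatic ring: a number 2 percentage points lower from compound 3 to compound 4 (within the scatter), so hydrogen in place of methyl does not separate the two compounds at the concentration tested. With the 3-hydroxy-5-methylphenyl group common to both compounds, dimethylamino in place of phenoxy on an aromatic carbon gives no change at the digits printed from compound 2 to compound 4 (within the scatter), so this second change also leaves the compounds indistinguishable. No measurement is available that bears on why either step stays so small.

A single low concentration leaves open whether either change would matter at a concentration where these compounds give a clearly stronger effect. As far as these compounds go, it also remains open whether a longer chain such as ethoxy or an amine at this position would move the read-out beyond the scatter.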